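Isopropyl on the anilino ring: expected potency of compound 3

The compounds below may be only part of what the source reports. "The series", "measured", "known", "first", "only" and "open" are said of these compounds alone.

Compound 1 `CC(C)c1ccc(-c2nc(SCc3cn(CC(=O)NC(=O)Nc4ccccn4)nn3)nc(Nc3ccccc3)c2C#N)cc1`: 15800 nM
Compound 2 `COc1ccccc1Nc1nc(SCc2cn(CC(=O)NC(=O)Nc3ccccn3)nn2)nc(-c2ccc(C(C)C)cc2)c1C#N`: > 64000 nM

In a functional assay on MGC-803 cells (Homo sapiens) for inhibition, read by MTT assay, with a stated time of 72 h (a lower number here means a stronger inhibitor, a higher number a weaker inhibitor), compound 1 gives 15800 nM. For compound 2 this assay reports only a limit, > 64000 nM, and no number. For the measured compounds named here, compound 1 therefore holds the only number among the two results. Going by the values given here, the single measured step, methoxy in place of hydrogen on an aromatic carbon, reads an at least 4.0-fold higher number from compound 1 to compound 2 (0.60 log units; beyond the scatter); it rests on (the limit of > 64000 nM in this assay, at which 1 of the 2 values shown sits).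

Compound 3 `CC(C)c1ccc(Nc2nc(SCc3cn(CC(=O)NC(=O)Nc4ccccn4)nn3)nc(-c3ccc(C(C)C)cc3)c2C#N)cc1` differs from compound 1 by isopropyl in place of hydrogen on an aromatic carbon of a six-membered aromatic ring of carbon only, para to a large group, turning anilino into (4-isopropylphenyl)amino. Among the compounds with values here, the one measured step alters the same anilino ring, yet with a different group at a different place, so it gives no direction for this change. The number for compound 3 is therefore expected close to that of compound 1, and the step of a 1.3-fold higher number from compound 1 to compound 3 (0.10 log units; within the scatter) is expected to stay within the scatter. Compound 3 is estimated at 20000 nM, between 6000 nM and 64000 nM.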

Compound 3, half-maximal inhibitory concentration: 15800 nM
Estimate against measurement, compound 3: 1.3-fold (0.10 log units) above, within the range that was stated.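

In this assay, the anilino ring accepts an isopropyl group para to a large group with no loss, giving no change at the digits printed from compound 1 to compound 3 (within the scatter). Replacing 2-methoxyphenyl with 4-isopropylphenyl on the nitrogen gives an at least 4.0-fold lower number from compound 2 to compound 3 (0.60 log units; beyond the scatter), so substituents on this ring do not all read alike, and the isopropyl change shows that a substituent here need not raise the number. Compound 2 has only a limit, > 64000 nM, and not a number, so the size of that step stays open: the limit of > 64000 nM in this assay, at which 1 of the 3 values shown sits.

On these data alone, whether an amine, a carboxylic acid or a longer chain in place of the isopropyl would also leave the number unchanged remains open. Compound 2 and compound 3 differ in both the group and where it sits on the ring, and the compounds shown do not separate these two changes.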